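From 4-cyanobenzyl to 3-bromobenzyl in the series

The compounds below may be only part of what the source reports. "The series", "measured", "known", "first", "only" and "open" are said of these compounds alone.

In a functional assay on HepG2 cells (Homo sapiens) for antiproliferative activity, read by MTT assay, with a stated time of 24 h (a higher number here means a weaker inhibitor, a lower number a stronger inhibitor), compound 1 (`COc1cc(OC)c(-c2coc3cc(OCc4ccc(F)cc4)ccc3c2=O)cc1OC`) reads 1000 nM and stands apart from the other two measured compounds. Compound 2 (`COc1cc(OC)c(-c2coc3cc(OCc4ccc([N+](=O)[O-])cc4)ccc3c2=O)cc1OC`) reads 2500 nM and compound 3 (`COc1cc(OC)c(-c2coc3cc(OCc4ccc(C#N)cc4)ccc3c2=O)cc1OC`) reads 4230 nM in this assay on the same core. Compound 3 shares the high end of the numbers with one neighbour and is clearly separated from the other: a 1.7-fold higher number from compound 2 to compound 3 (0.23 log units; within the scatter) is no real gap, whereas a 4.2-fold higher number from compound 1 to compound 3 (0.63 log units; beyond the scatter) is one. The remaining measured step, a 2.5-fold higher number from compound 1 to compound 2 (0.40 log units; beyond the scatter), is of similar modest size.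

Among the compounds with values here, compound 4 (`COc1cc(OC)c(-c2coc3cc(OCc4cccc(Br)c4)ccc3c2=O)cc1OC`) is reached by 3-bromophenyl in place of 4-cyanophenyl on a saturated chain carbon bound to an oxygen on an aromatic ring as the only change, 3-bromophenyl in place of 4-cyanophenyl. Within the data shown here, no measured compound carries bromine, and all three measured compounds have their group at the same ring place, so the evidence is indirect. Among the measured compounds shown here, the closest guide is compound 1 at 1000 nM as the only measured compound with a halogen on this ring. A modest move to a lower number is therefore expected, and a 2.4-fold lower number from compound 3 to compound 4 (0.37 log units; beyond the scatter) is the estimated step. Compound 4 is estimated at 1800 nM with an expected range from 700 nM to 4500 nM in this assay for now.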

Compound 4, half-maximal inhibitory concentration: 870 nM
Compound 4: the middle estimate sits 2.1-fold (0.32 log units) above what was measured; the range from low to high includes it.
By their numbers in this assay, from the lowest: compounds 4 and 1 (each within the scatter of the next); then compounds 2 and 3 (each within the scatter of the next).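

In this assay, within the data shown here, 3-bromophenyl on a saturated chain carbon bound to an oxygen on an aromatic ring gives a 4.9-fold lower number from compound 3 to compound 4 (0.69 log units; beyond the scatter) and a 2.9-fold lower number from compound 2 to compound 4 (0.46 log units; beyond the scatter), so 4-fluorophenyl is no longer the only group at the low end of the numbers. With a 1.1-fold lower number from compound 1 to compound 4 (0.06 log units; within the scatter), the swap of 4-fluorophenyl for 3-bromophenyl, which alters the halogen and its ring place together, leaves no readable shift, and the two halogen-bearing compounds stand as a pair apart from the 4-nitrophenyl and 4-cyanophenyl compounds, with no compound shown going against that split. No accompanying measurement speaks to what lies behind these differences.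

Compound 1 and compound 4 cannot separate the halogen from its ring place, a question that 3-fluorophenyl and 4-bromophenyl would address directly. Also open, from the compounds shown here alone, is whether the low end of the numbers extends beyond halogens, for instance to 3-aminophenyl, to 3-carboxyphenyl or to a longer chain on the same oxygen.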